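Swapping a trimethylphenyl for a difluorophenyl on a hydrazone

This account rests on a few compounds, and the source may have more. Where it says the series, first, only, none or still open, it means among the compounds named here.

Of the compounds shown here, three sharing one core have been tested in a functional assay on HCT-116 cells (Homo sapiens) for antiproliferative activity, read by MTT assay; on this read-out higher numbers stand for weaker inhibition and lower numbers for stronger inhibition. Compound 1 `Cn1c(=O)c(=O)n(C2CCCC2)c2nc(N/N=C/c3ccc(Cl)cc3)ncc21` gives 9810 nM. Compound 2 `Cc1cc(C)c(/C=N/Nc2ncc3c(n2)n(C2CCCC2)c(=O)c(=O)n3C)c(C)c1`, which carries a 2,4,6-trimethylphenyl in place of the 4-chlorophenyl, gives 7920 nM; the step of a 1.2-fold lower number from compound 1 to compound 2 (0.09 log units; within the scatter) is within the scatter, so the two are indistinguishable on this read-out. Compound 3 `COc1ccc(/C=N/Nc2ncc3c(n2)n(C2CCCC2)c(=O)c(=O)n3C)c(OC)c1` is reported only as a limit, > 100000 nM, not as a number. Against that limit the steps of an at least 10-fold higher number from compound 1 to compound 3 (1.00 log units; beyond the scatter) and an at least 12-fold higher number from compound 2 to compound 3 (1.10 log units; beyond the scatter) are both clearly beyond the scatter, and the limit of > 100000 nM in this assay, at which 1 of the 3 values shown sits, shows how far the measured range reaches.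

Compound 4 `Cn1c(=O)c(=O)n(C2CCCC2)c2nc(N/N=C/c3ccc(F)cc3F)ncc21` has not yet been measured. It differs from compound 2 in one place: 2,4-difluorophenyl in place of 2,4,6-trimethylphenyl on a carbon with a double bond to nitrogen. The closest guidance comes from compound 1, whose 4-chlorophenyl is also a halogenated ring and sits within the scatter of compound 2, while compound 3 shows that a 2,4-disubstituted ring can lose activity entirely. A 2,4-pattern on compound 2 itself is tolerated, so the expected step of a 1.5-fold higher number from compound 2 to compound 4 (0.18 log units; within the scatter) is small, with the uncertainty leaning toward a weaker result. Compound 4 is therefore estimated at 12000 nM, in this assay, with a range from 4000 nM to 60000 nM.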

Compound 4, half-maximal inhibitory concentration: 19800 nM
Beside the measured number, compound 4's estimate is 1.7-fold (0.22 log units) below it, within the range that was stated.
By their numbers in this assay, from the lowest: compounds 2, 1 and 4 (each within the scatter of the next, the first and the last beyond it). At a limit, above all of these: compound 3.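

Among the compounds with measured numbers, changing the ring on the carbon with a double bond to nitrogen now gives a difference beyond the scatter for the first time: the step of a 2.5-fold higher number from compound 2 to compound 4 (0.40 log units; beyond the scatter) is modest but clear, whereas the step of a 2.0-fold higher number from compound 1 to compound 4 (0.30 log units; within the scatter) stays within the scatter, so 2,4-difluorophenyl and 4-chlorophenyl cannot be told apart on this read-out. The step of an at least 5.0-fold lower number from compound 3 to compound 4 (0.70 log units; beyond the scatter) shows that substitution at the 2 and 4 positions of the ring does not by itself remove activity, since 2,4-difluorophenyl gives a measured number where 2,4-dimethoxyphenyl does not. For compound 3, that comparison rests on a limit and not a number: the limit of > 100000 nM in this assay, at which 1 of the 4 values shown sits.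

Going by these compounds, these values cannot say what separates the rings, and it remains open whether a 4-methoxyphenyl, with a single methoxy group, would fall near compound 1 or near compound 3. On these data alone, how the shared core would respond to an amine or a carboxylic acid on this ring, or to a pyridine ring in place of the phenyl, also remains open.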